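The compounds below may be only part of what the source reports. "The series", "measured", "known", "first", "only" and "open" are said of these compounds alone.

For the measured compounds named here, compound 1 `COc1ccc(C(=O)/C=C/c2ccc(N(C)C)cc2)c2c1C=CC(C)(C)O2` is the only compound of this set with a number rather than a limit: in a functional assay on HepG2 cells (Homo sapiens) for antiproliferative activity, read by MTT assay, with a stated time of 24 h (on this read-out higher numbers stand for weaker inhibition and lower numbers for stronger inhibition), compound 1 gives 730 nM. Compound 2 `COc1ccc(C(=O)/C=C/c2ccc(-c3ccccc3)cc2)c2c1C=CC(C)(C)O2` differs from it by phenyl in place of dimethylamino on an aromatic carbon. In this assay compound 2 gives > 10000 nM, which is a limit of the assay and not a number. The step of an at least 13-fold higher number from compound 1 to compound 2 (1.13 log units; beyond the scatter) is therefore known only as a lower bound, set by the limit of > 10000 nM in this assay, at which 1 of the 2 values shown sits.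

Compound 3 `COc1ccc(C(=O)/C=C/c2ccc(O)c(Br)c2)c2c1C=CC(C)(C)O2` carries a different change at the same end of the molecule: 3-bromo-4-hydroxyphenyl in place of 4-(dimethylamino)phenyl on a double-bonded chain carbon bound to a double-bonded chain carbon. Going by the values given here, the one measured step bears on it only in part, since it too removes the dimethylamino, and there the loss was large. The value of compound 3 is therefore expected to be weaker than compound 1, with a step of a 4.8-fold higher number from compound 1 to compound 3 (0.68 log units; beyond the scatter) beyond the scatter. In this assay compound 3 is estimated at 3500 nM, within a range from 1000 nM to 12000 nM.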

Compound 3, half-maximal inhibitory concentration: > 10000 nM
Compound 3: no number, only a limit; the forecaster's own chance of this, stated with the estimate: 30%; at least 2.8-fold (0.45 log units) between middle value and limit.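

In this assay, 3-bromo-4-hydroxyphenyl in place of 4-(dimethylamino)phenyl gives an at least 13-fold higher number from compound 1 to compound 3 (1.13 log units; beyond the scatter), and that size is only a lower bound, set by a limit of the assay: the limit of > 10000 nM in this assay, at which 2 of the 3 values shown sit. This is a second, quite different replacement at this place on the chain, one that brings in a hydrogen-bond donor, and like the phenyl-bearing group of compound 2 it fails to keep the number of compound 1. For the compounds shown here, compound 2 and compound 3 both stand at a limit, so no step between them can be read.

The hydroxyl and the bromine enter together, so the compounds shown cannot tell what each does alone. They also leave open whether the dimethylamino group itself matters, which a 4-aminophenyl or 4-(diethylamino)phenyl group at this place would test.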